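Swapping the meta substituent on the sulfonamide aryl ring

This account rests on a few compounds, and the source may have more. Where it says the series, first, only, none or still open, it means among the compounds named here.

Compound 2 `O=S(=O)(Nc1ccc(-c2nc3ccccc3o2)cc1)c1cccc(C(F)(F)F)c1` was tested in an assay on cells for inhibition of HSP60/HSP10 (Homo sapiens), with a stated time of 60 min (a lower number here means a stronger inhibitor, a higher number a weaker inhibitor), and gives 57000 nM. Its closest neighbour, compound 1 `O=S(=O)(Nc1ccc(-c2nc3ccccc3o2)cc1)c1cccc(O)c1`, gives 62000 nM in this assay, so the two numbers sit together within the usual scatter. The step of a 1.1-fold lower number from compound 1 to compound 2 (0.04 log units; within the scatter) is the only one that bears on the change now considered, and it shows that exchanging hydroxy for trifluoromethyl at this position left the number essentially unchanged. Compound 3 `COc1cccc(S(=O)(=O)Nc2ccc(-c3nc4ccccc4o3)cc2)c1` differs from compound 2 in one place: methoxy in place of trifluoromethyl on an aromatic carbon. Because the measured step of a 1.1-fold lower number from compound 1 to compound 2 (0.04 log units; within the scatter) lay within the scatter, a third substituent of this kind at the same position is expected to behave much the same, with no step beyond the scatter in this assay in either direction. The estimate for compound 3 is therefore 60000 nM, with a range from 25000 nM to 150000 nM, which corresponds to an expected step of a 1.1-fold higher number from compound 2 to compound 3 (0.02 log units; within the scatter).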

Compound 3, half-maximal inhibitory concentration: 80000 nM
For compound 3 the middle estimate is 1.3-fold (0.12 log units) below the measured one; the range from low to high includes it.
By their numbers in this assay, from the lowest: compounds 2, 1 and 3 (each within the scatter of the next).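

Methoxy adds a third group at this position, and this assay still does not separate it from the other two, either on exchange for trifluoromethyl (a 1.4-fold higher number from compound 2 to compound 3 (0.15 log units; within the scatter)) or on placing methyl on the hydroxy oxygen (a 1.3-fold higher number from compound 1 to compound 3 (0.11 log units; within the scatter)). The hydrogen on that oxygen can therefore be replaced by methyl without a step beyond the scatter, and the same holds when a group with one hydrogen-bond acceptor takes the place of one with none. Nothing available explains why these three groups read alike.

The three compounds leave open whether an amine, a carboxylic acid or a longer chain such as butoxy at this position would give a step beyond the scatter. They also leave open whether any group here can move the number that far in either direction.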